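The source may report more compounds than this note shows. Statements on the series, on what has been measured and on what is new or still open speak of the compounds shown alone.

In a functional assay on PC-3 cells (Homo sapiens) for antiproliferative activity, read by MTT assay, with a stated time of 48 h (a lower number here means a stronger inhibitor of growth, a higher number a weaker inhibitor of growth), three compounds sharing one core and differing in a single saturated chain have been measured: compound 1 `CCCCCN(Cc1ccc(C(=O)NO)cc1)c1ncc(-c2ccc(C)cc2)s1` gives (5060 nM), compound 2 `Cc1ccc(-c2cnc(N(Cc3ccc(C(=O)NO)cc3)CC(C)C)s2)cc1` gives (9340 nM) and compound 3 `CCN(Cc1ccc(C(=O)NO)cc1)c1ncc(-c2ccc(C)cc2)s1` gives (10300 nM). Compound 3 therefore stands level with compound 2 (a 1.1-fold higher number from compound 2 to compound 3 (0.04 log units; within the scatter)), but it is modestly separated from compound 1 (a 2.0-fold higher number from compound 1 to compound 3 (0.31 log units; beyond the scatter)). The next compound, compound 4 `Cc1ccc(OCCCN(Cc2ccc(C(=O)NO)cc2)c2ncc(-c3ccc(C)cc3)s2)cc1`, is reached from compound 3 by placing (4-methylphenoxy)methyl in place of hydrogen on a saturated chain carbon, two bonds along the chain from a nitrogen on an aromatic ring. Within the data shown here, the step that bears most directly is the one between compound 1 and compound 3, which concerns the same carbon and, read backwards, shows that a propyl group there goes with a lower number. The remaining step (a 1.8-fold higher number from compound 1 to compound 2 (0.27 log units; within the scatter)) shows how little these chain changes have moved the numbers. Among the measured compounds shown here, no measured compound has an aromatic ring or an oxygen in this chain, so the analogy is loose. A modest step towards a lower number is expected, and it may stay within the scatter. Compound 4 is expected at about 5500 nM (estimated range 2200 nM to 12000 nM). This estimate corresponds to an expected change (a 1.9-fold lower number from compound 3 to compound 4 (0.27 log units; within the scatter)).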

Compound 4, concentration for 50% growth inhibition: 9330 nM
Beside the measured number, compound 4's estimate is 1.7-fold (0.23 log units) below it; the measured number falls inside the stated range.
By their numbers in this assay, from the lowest: compounds 1, 4, 2 and 3 (each within the scatter of the next, the first and the last beyond it).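

In this assay, placing (4-methylphenoxy)methyl on the saturated chain carbon, two bonds along the chain from a nitrogen on an aromatic ring, leaves the number level, with a 1.1-fold lower number from compound 3 to compound 4 (0.04 log units; within the scatter), so this position takes a much larger group containing an aromatic ring and an oxygen without any step beyond the scatter. Among these compounds, the new chain also stands level with the two other chains, with a 1.0-fold lower number from compound 2 to compound 4 (0.00 log units; within the scatter) and with a 1.8-fold higher number from compound 1 to compound 4 (0.27 log units; within the scatter), which means the 3-(4-methylphenoxy)propyl chain does not set compound 4 apart from any compound measured so far, whereas the saturated chains of compound 1 and compound 3 are separated beyond the scatter. Nothing measured here accounts for this result.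

The compounds shown leave open whether the oxygen plays any part in this outcome, as no chain here carries the aromatic ring on an all-carbon link such as 4-(4-methylphenyl)butyl. They also leave open whether an amine or a carboxylic acid at the end of this chain would move the number beyond the scatter.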